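A few compounds are considered here, and "the series" means these few. Any claim that something is new, unique, unknown or untested is made for them only; others in the source may bear on it.

Measured compounds:
- compound 1, `O/N=C(/Nc1cccc(F)c1)c1ccc2occc2c1`, in an assay on isolated protein for inhibition of Indoleamine 2,3-dioxygenase 1 (Homo sapiens), read by spectrophotometry; a higher number here means a weaker inhibitor, a lower number a stronger inhibitor: 32700 nM
- compound 2, `O/N=C(/Nc1cccc(C(F)(F)F)c1)c1ccc2occc2c1`, in this assay: 1200 nM
- compound 3, `CC(=O)c1cccc(N/C(=N/O)c2ccc3occc3c2)c1`, in this assay: > 30000 nM

Compound 3 stands at the weak end of the set. Its result in this assay is a limit of the assay and not a number, so its true value could lie anywhere beyond (the limit of > 30000 nM in this assay, at which 1 of the 3 values shown sits). The two steps that reach compound 3 are therefore only partly readable: a step that the limit leaves unreadable from compound 1 to compound 3, and an at least 25-fold higher number from compound 2 to compound 3 (1.39 log units; beyond the scatter). Among the measured compounds shown here, the one fully readable step, a 27-fold lower number from compound 1 to compound 2 (1.44 log units; beyond the scatter), concerns a change that compound 4 does not share.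

Compound 4, `O=C(NCc1ccccc1)c1cccc(N/C(=N/O)c2ccc3occc3c2)c1`, differs from compound 3 in one place: benzylamino in place of methyl on a carbonyl carbon. For the measured compounds named here, no measured step touches the carbonyl carbon or a benzylamino group, so nothing among the measured pairs says whether this change should raise or lower the number. Going by the values given here, what the two steps into compound 3 show is only that a carbonyl group at this position sits at the limit; whether an amide behaves like the acetyl is not tested.

The expectation for compound 4 in this assay is therefore a weak inhibitor, roughly 25000 nM, within 5000 nM to 100000 nM, with a fair chance that the assay again reports only a limit. The step that this estimate implies, an at least 1.2-fold lower number from compound 3 to compound 4 (0.07 log units; that floor lies within the scatter), is expected to lie within the scatter.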

Compound 4, half-maximal inhibitory concentration: > 30000 nM
Compound 4 ended at the assay's limit (the forecaster's own chance of this, stated with the estimate: 50%); middle value at least 1.2-fold (0.07 log units) from the limit.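

Compound 3 and compound 4 both end at a limit of this assay and not at a number, so no step between them can be read: the limit of > 30000 nM in this assay, at which 2 of the 4 values shown sit.

The compounds shown leave open whether benzylamino in place of methyl on the carbonyl carbon changes inhibition at all, and how far past the limit either compound truly lies.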